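This account rests on a few compounds, and the source may have more. Where it says the series, first, only, none or still open, it means among the compounds named here.

Compound 1, `COc1ccc(C(c2ccccc2O)c2cccc3ccccc23)c(OC)c1OC`: in a functional assay on THP-1 cells (Homo sapiens) for inhibition, read by sulforhodamine B assay, with a stated time of 48 h (a higher number here means a weaker inhibitor, a lower number a stronger inhibitor), compound 1 gives > 20000 nM, a limit.
Compound 2, `COc1cc(COC(c2ccc(OC)c(OC)c2OC)c2cccc3ccccc23)cc(OC)c1`: in this assay compound 2 gives > 20000 nM, a limit.
Compound 3, `C=CCOC(c1ccc(OC)c(OC)c1OC)c1cccc2ccccc12`: in this assay compound 3 gives > 20000 nM, a limit.

Compound 3 stands at the limit of this assay, as the limit of > 20000 nM in this assay, at which 3 of the 3 values shown sit, records for every value shown. The steps a step that the two limits leave unreadable from compound 1 to compound 3 and a step that the two limits leave unreadable from compound 2 to compound 3 are both unreadable, since each runs between two limits. Compound 4, `COc1ccc(C(OCc2ccc(C)cc2)c2cccc3ccccc23)c(OC)c1OC`, differs from compound 3 at one place: 4-methylphenyl in place of vinyl on a saturated chain carbon bound to an oxygen on a saturated carbon. Within the data shown here, no measured step shows a read at this place, so no direction beyond the scatter can be expected. The step that the limit leaves unreadable from compound 3 to compound 4 is therefore expected to stay near no change. Compound 4 is estimated in this assay at 30000 nM, between 8000 nM and 100000 nM, most likely again a limit.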

Compound 4, half-maximal inhibitory concentration: > 20000 nM
Compound 4: no number, only a limit; the forecaster's own chance of this, stated with the estimate: 75%; the middle value does not contradict the limit.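

Compound 4 also gives only a limit, so no step from compound 1, compound 2 or compound 3 to compound 4 can be read, and every value shown sits at one point: the limit of > 20000 nM in this assay, at which 4 of the 4 values shown sit.

The compounds shown leave open which change to the shared core, if any, would give a number rather than a limit in this assay.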